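Swapping 4-hydroxyphenyl for 2,3-dichlorophenyl in compound 4

The source may report more compounds than this note shows. Statements on the series, on what has been measured and on what is new or still open speak of the compounds shown alone.

Measured in a functional assay on MCF7 cells (Homo sapiens) for cytotoxicity, read by MTT assay, with a stated time of 72 h; a lower number here means a stronger inhibitor, a higher number a weaker inhibitor
Compound 1 `COc1ccccc1/C=C1\CCC/C(=C\c2ccc(OC)c(OC)c2)C1=O` gives 8000 nM
Compound 2 `COc1cccc(/C=C2\CCC/C(=C\c3ccc(OC)c(OC)c3)C2=O)c1` gives 4600 nM
Compound 3 `COc1ccc(/C=C2\CCC/C(=C\c3ccc(O)cc3)C2=O)cc1OC` gives 17000 nM

Compound 3 has the highest number of the three, which makes it the weakest inhibitor here. Compound 4 `COc1ccc(/C=C2\CCC/C(=C\c3cccc(Cl)c3Cl)C2=O)cc1OC` keeps the rest of compound 3 but carries 2,3-dichlorophenyl in place of 4-hydroxyphenyl, on a double-bonded chain carbon bound to a double-bonded ring carbon (2,3-dichlorophenyl in place of 4-hydroxyphenyl on a double-bonded chain carbon bound to a double-bonded ring carbon).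

For the measured compounds named here, two measured steps bear on this place, and both end at the 4-hydroxyphenyl of compound 3: a 2.1-fold higher number from compound 1 to compound 3 (0.33 log units; beyond the scatter) and a 3.7-fold higher number from compound 2 to compound 3 (0.57 log units; beyond the scatter). Both are modest. Read backwards, they show that the two compounds with a methoxyphenyl at this place have lower numbers. Going by the values given here, no compound with a dichlorophenyl has been measured, so these steps are only a rough guide. A modest drop in this assay is expected, a 2.8-fold lower number from compound 3 to compound 4 (0.45 log units; beyond the scatter). For compound 4 the estimated value is 6000 nM, with an expected range from 2000 nM to 16000 nM.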

Compound 4, half-maximal inhibitory concentration: 14300 nM
The estimate for compound 4 lay 2.4-fold (0.38 log units) below the measured number; low and high end bracket the measured number.
By their numbers in this assay, from the lowest: compounds 2, 1, 4 and 3 (each within the scatter of the next, the first and the last beyond it).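

In this assay, exchanging the 4-hydroxyphenyl for 2,3-dichlorophenyl gives a 1.2-fold lower number from compound 3 to compound 4 (0.08 log units; within the scatter), so the two groups cannot be told apart here, even though the group that leaves has a hydrogen-bond donor and acceptor and the group that enters has neither. Against the methoxyphenyl compounds, the picture is split: there is a 3.1-fold higher number from compound 2 to compound 4 (0.49 log units; beyond the scatter), while a 1.8-fold higher number from compound 1 to compound 4 (0.25 log units; within the scatter), so only the 3-methoxyphenyl of compound 2 stands apart from the dichlorophenyl group at this place. No measurement at hand offers a reason for either result.

The compounds shown leave open whether a phenyl ring carrying an amine or a carboxylic acid would stand apart from these values. They also leave open whether a single chlorine would behave like the pair.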